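The source may hold more compounds than are shown below. What is called first, only, known or untested is meant among the compounds shown, and "the series" means these compounds.

Measured compounds and their values:

Compound 1, `Cn1c(-c2ccc(NC(=O)CN3CCN(c4ccccc4)CC3)cc2)nc(-c2ccccc2)c1-c1ccccc1`: 46.5%
Compound 2, `Cn1c(-c2ccc(NC(=O)CN3CCN(Cc4ccccc4)CC3)cc2)nc(-c2ccccc2)c1-c1ccccc1`: 26.8%

Both compounds were tested in a functional assay on HT-29 cells (Homo sapiens) for cytotoxicity, read by MTT assay, with a stated time of 24 h, tested at 6.4 ug/mL; a higher number here means a stronger effect of the compound at the concentration tested, a lower number a weaker effect. Among the measured compounds shown here, compound 2 gives 26.8%, the lower of the two numbers; the only measured step, a number 19.7 percentage points lower from compound 1 to compound 2 (beyond the scatter), runs downward and is larger than the usual scatter. Compound 3, `Cc1ccc(CN2CCN(CC(=O)Nc3ccc(-c4nc(-c5ccccc5)c(-c5ccccc5)n4C)cc3)CC2)cc1`, is the next compound in the series. It differs from compound 2 by a single small change, (methyl in place of hydrogen on an aromatic carbon). For the measured compounds named here, no measured step concerns this kind of change: the one step in hand swaps a phenyl for a benzyl on a ring nitrogen, which is a different matter and gives no guide to adding a methyl on an aromatic carbon. With nothing comparable to lean on, the expectation is no step beyond the scatter. Compound 3 is therefore expected to give about 28%, with a plausible range from 13% to 43%. The expected step from its parent is a number 1.2 percentage points higher from compound 2 to compound 3 (within the scatter).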

Compound 3, a percentage reported as activity, at one concentration (the size of the read-out at that concentration, not a potency): 27.7%
The estimate for compound 3 lay 0.3 percentage points above the measured number; the range from low to high includes it.
By their numbers in this assay, from the lowest: compounds 2 and 3 (each within the scatter of the next); then compound 1.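

In this assay, turning benzyl into 4-methylbenzyl gives a small shift (a step of a number 0.9 percentage points higher from compound 2 to compound 3 (within the scatter)), so a methyl at this ring position, para to a large group, leaves the read-out where it was. Set against the phenyl of compound 1, the 4-methylbenzyl group still gives a clear drop (a number 18.8 percentage points lower from compound 1 to compound 3 (beyond the scatter)), so compound 3 sits with compound 2 and the drop seen with benzyl also holds with this methylated version. No measurement shown here offers an explanation for these numbers.

Open, on these data alone, is whether a larger or different group at the same ring position, such as methoxy, chlorine or hydroxyl, would behave like methyl, and whether a phenethyl group would behave like benzyl. Also open, as far as these compounds go, is whether a methyl on the phenyl of compound 1 would matter as little.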